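Estimating the half-life of a bromo and methoxy analogue

The source may report more compounds than this note shows. Statements on the series, on what has been measured and on what is new or still open speak of the compounds shown alone.

In an ADME assay on microsomes from liver (Rattus norvegicus) for metabolic stability, read by LC-MS, using NADPH, at 37 degrees C (on this read-out higher numbers stand for a longer-lived compound and lower numbers for a shorter-lived compound), compound 1 `Cc1oc(-c2c(F)cccc2F)nc1CN1CCC(C(=O)NCCCN2C[C@H](C)C[C@H](C)C2)CC1` gives 0.35 h, compound 2 `Cc1oc(-c2c(Cl)cccc2Br)nc1CN1CCC(C(=O)NCCCN2C[C@H](C)C[C@H](C)C2)CC1` gives 0.0233 h and compound 3 `Cc1oc(-c2c(Cl)cccc2C(F)(F)F)nc1CN1CCC(C(=O)NCCCN2C[C@H](C)C[C@H](C)C2)CC1` gives 0.03 h. The measured steps show a 15-fold lower number from compound 1 to compound 2 (1.18 log units; beyond the scatter) and a 12-fold lower number from compound 1 to compound 3 (1.07 log units; beyond the scatter), both large, against a 1.3-fold higher number from compound 2 to compound 3 (0.11 log units; within the scatter), which lies within the scatter. Compound 3 therefore stands level with compound 2 and far from compound 1.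

Compound 4 `COc1cccc(Br)c1-c1nc(CN2CCC(C(=O)NCCCN3C[C@H](C)C[C@H](C)C3)CC2)c(C)o1` brings a further change to compound 3: 2-bromo-6-methoxyphenyl in place of 2-chloro-6-(trifluoromethyl)phenyl on an aromatic carbon. Going by the values given here, the 2-bromo-6-methoxyphenyl group keeps the bromo of compound 2, which gives 0.0233 h, and no measured compound carries a methoxy, so that part of the change remains untested. Exchanging trifluoromethyl for bromo moved the number only within the scatter, and nothing measured points to a return towards compound 1, so the expectation stays close to the lower pair.

The expected change in this assay is a 1.2-fold lower number from compound 3 to compound 4 (0.08 log units; within the scatter), which is no step beyond the scatter. For compound 4 the estimated half-life is 0.025 h, with an expected range from 0.01 h to 0.08 h.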

Compound 4, half-life: 0.0583 h
Estimate against measurement, compound 4: 2.3-fold (0.37 log units) below, and the stated range covers the measured number.
By their numbers in this assay, from the lowest: compounds 2, 3 and 4 (each within the scatter of the next, the first and the last beyond it); then compound 1.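

In this assay, methoxy in place of chloro, with the bromo kept, gives a 2.5-fold higher number from compound 2 to compound 4 (0.40 log units; beyond the scatter), so this position responds to methoxy by a step beyond the scatter, which the exchange of trifluoromethyl for bromo did not show. Exchanging the whole substituent gives a 1.9-fold higher number from compound 3 to compound 4 (0.29 log units; within the scatter), while the 2-bromo-6-methoxyphenyl group still stays well short of the 2,6-difluorophenyl group, with a 6.0-fold lower number from compound 1 to compound 4 (0.78 log units; beyond the scatter). No measurement at hand offers an explanation for these differences.

Going by these compounds, what remains open is whether a single fluoro group paired with methoxy would move the number towards that of compound 1, or whether both fluoro groups are needed. How hydroxy or ethoxy in place of the methoxy would read here is also unknown.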